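Shortening the chain on compound 2

The source may report more compounds than this note shows. Statements on the series, on what has been measured and on what is new or still open speak of the compounds shown alone.

Measured so far in a functional assay on MIA PaCa-2 cells (Homo sapiens) for antiproliferative activity, read by MTT assay, with a stated time of 3 days (a lower number here means a stronger inhibitor, a higher number a weaker inhibitor), for three compounds:
Compound 1 `O=C1c2ccccc2C(=O)N1C/C=C\Cn1cc(C#Cc2ccc(Br)cc2)c(=O)[nH]c1=O` gives > 100000 nM which is a limit
Compound 2 `CCCCCCC#Cc1cn(C/C=C/CN2C(=O)c3ccccc3C2=O)c(=O)[nH]c1=O` gives 30000 nM as a number
Compound 3 `O=C1c2ccccc2C(=O)N1C/C=C\Cn1cc(C#CCCc2ccccc2)c(=O)[nH]c1=O` gives > 100000 nM which is a limit

Compound 2 gives 30000 nM and is the only one of the three with an actual number. The other two values are limits.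

Compound 4 `CCCCC#Cc1cn(C/C=C/CN2C(=O)c3ccccc3C2=O)c(=O)[nH]c1=O` differs from compound 2 in one place, as hydrogen in place of ethyl on a saturated chain carbon, four bonds along the chain from a triple-bonded carbon with hydrogen in place of ethyl on a saturated chain carbon, four bonds along the chain from a triple-bonded carbon. The chain is therefore shorter.

For the measured compounds named here, the one step between measured compounds is a step that the two limits leave unreadable from compound 1 to compound 3 and it gives no size to carry over. The other guide is the limit of > 100000 nM in this assay, at which 2 of the 3 values shown sit, in this small set. Going by the values given here, no measured step shows what chain length does here, so any forecast is loose. A modest move toward a weaker value is expected, resting on compound 2 at 30000 nM. That expectation also rests on the limit just mentioned. The expected change is a 1.7-fold higher number from compound 2 to compound 4 (0.22 log units; within the scatter) and it remains only an estimate. Compound 4 may also be reported only as a limit. Compound 4 is estimated at 50000 nM with an expected range from 15000 nM to 100000 nM on this reading.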

Compound 4, half-maximal inhibitory concentration: 77000 nM
Estimate against measurement, compound 4: 1.5-fold (0.19 log units) below; measured number inside the range.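

In this assay, removing ethyl from a saturated chain carbon, four bonds along the chain from a triple-bonded carbon, and leaving hydrogen in its place gives a 2.6-fold higher number from compound 2 to compound 4 (0.41 log units; beyond the scatter). For the compounds shown here, this is the first step in the set with a readable size, and it shows that the length of this saturated chain matters in this assay: the shorter chain of compound 4 gives the weaker result, and the change lies beyond the usual scatter of repeated measurements. The earlier step between compound 1 and compound 3 cannot be read, whereas compound 2 and compound 4 both give actual numbers, so this comparison stands apart from the values that are only limits: the limit of > 100000 nM in this assay, at which 2 of the 4 values shown sit.

Going by these compounds alone, one step joins only two chain lengths, so it cannot show whether a longer chain, such as a decyl group, would continue the same trend or reverse it. Also unknown is how the result would change if an amine or a carboxylic acid stood at the far end of the chain, since neither group appears among the compounds shown.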